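Methyl for hydrogen on the aromatic amine: cytotoxicity notes

The source may hold more compounds than are shown below. What is called first, only, known or untested is meant among the compounds shown, and "the series" means these compounds.

Measured so far:
compound 1 `CC(=O)Nc1ccc(-c2nn(Cc3ccc(C#N)cc3)c(=O)c3ccccc23)c(F)n1` — > 100000 nM
compound 2 `CNc1ccc(-c2nn(Cc3ccc(C#N)cc3)c(=O)c3ccccc23)c(F)n1` — > 100000 nM

In an ADME assay on HepG2 2.2.15 cells (Homo sapiens) for cytotoxicity, read by MTT assay, with a stated time of 8 days (on this read-out higher numbers stand for lower toxicity in this test and lower numbers for higher toxicity in this test), compound 1 gives > 100000 nM, which is a limit of the test and not a number. Compound 2 gives > 100000 nM in this assay, again a limit. The step that the two limits leave unreadable from compound 1 to compound 2 is therefore not readable in size. Compound 2 stands at the limit of > 100000 nM in this assay, at which 2 of the 2 values shown sit, the only mark the series has so far in this assay.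

Compound 3 `CN(C)c1ccc(-c2nn(Cc3ccc(C#N)cc3)c(=O)c3ccccc23)c(F)n1` is obtained from compound 2 by methyl in place of hydrogen on a nitrogen on an aromatic ring. Among the compounds with values here, the single measured step in this assay also changes the substituent on this nitrogen, but it sits between two limits and gives no size to carry over. Nothing among the two values speaks for a change beyond the scatter. Compound 3 is therefore expected to come back as a limit too, with an estimate of 150000 nM (range 50000 nM to 500000 nM), a step that the limit leaves unreadable from compound 2 to compound 3 that is expected to be unreadable in the same way.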

Compound 3, half-maximal cytotoxic concentration: 79200 nM
For compound 3 the middle estimate is 1.9-fold (0.28 log units) above the measured one, within the range that was stated.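

In this assay, within the data shown here, compound 3 gives 79200 nM as the first value that is a number and not a limit. Methyl in place of hydrogen on this nitrogen gives an at least 1.2-fold lower number from compound 2 to compound 3 (0.10 log units; that floor lies within the scatter) and dimethylamino in place of acetamido gives an at least 1.2-fold lower number from compound 1 to compound 3 (0.10 log units; that floor lies within the scatter) and both are floors only, so neither change can yet be placed beyond the scatter. The step between the other two compounds still cannot be read, and compound 1 and compound 2 stay at a limit of the test: the limit of > 100000 nM in this assay, at which 2 of the 3 values shown sit.

Open, going by these compounds, is whether a longer chain on this nitrogen, as in a diethylamino group, or a cyclic amine such as pyrrolidin-1-yl would move the number further. Also open, on these data alone, is what a free amino group in this place would give in this assay against these values.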